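Chain terminus changes and maximal response on the shared core

The compounds below may be only part of what the source reports. "The series", "measured", "known", "first", "only" and "open" are said of these compounds alone.

Measured so far in a functional assay on HEK293 cells for agonist activity at G-protein coupled receptor 84 (Homo sapiens), read by calcium flux; a lower number here means a smaller maximal response, a higher number a larger maximal response:
compound 1, `N#CCCCCc1nc(O)cc(O)n1` — 55.2%
compound 2, `CCCCCCc1nc(O)cc(O)n1` — 99.7%
compound 3, `CCCCCc1nc(O)cc(O)n1` — 84.9%

Compound 1 gives the lowest of the three numbers. Its nearest neighbour is compound 3, and the step of a number 29.7 percentage points higher from compound 1 to compound 3 (beyond the scatter) is beyond the scatter. The step of a number 44.5 percentage points higher from compound 1 to compound 2 (beyond the scatter) is larger still, and between the two all-carbon chains the step of a number 14.8 percentage points lower from compound 2 to compound 3 (beyond the scatter) shows that the longer chain is associated with the larger maximal response.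

The unmeasured compound 4, `CCCCCCCc1nc(O)cc(O)n1`, differs from compound 1 as follows: propyl in place of cyano on a saturated chain carbon, four bonds along the chain from an aromatic carbon. This change continues the same direction as the two measured steps from compound 1, since in both of them a carbon group enters where the cyano leaves, and the larger entering group in a number 44.5 percentage points higher from compound 1 to compound 2 (beyond the scatter) gave the bigger rise. Compound 4 carries the longest all-carbon chain of the set, and nothing measured here tells whether the maximal response keeps rising beyond compound 2 or levels off.

The expectation for compound 4 is therefore a step of about a number 44.8 percentage points higher from compound 1 to compound 4 (beyond the scatter), in the upward direction, landing near the value of compound 2; the estimate for compound 4 in this assay is 100%, with a range from 85% to 115%.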

Compound 4, largest response reached (reported as percent of maximum), in percent of the reference or control that the assay uses: 103%
For compound 4 the middle estimate is 3 percentage points below the measured one; low and high end bracket the measured number.
By their numbers in this assay, from the lowest: compound 1; then compound 3; then compounds 2 and 4 (each within the scatter of the next).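

In this assay the propyl group in place of cyano, on a saturated chain carbon four bonds along the chain from an aromatic carbon, keeps the response well clear of the nitrile-ended compound (a number 47.8 percentage points higher from compound 1 to compound 4 (beyond the scatter)), and ethyl in place of hydrogen at the position five bonds along the chain still stands beyond the scatter (a number 18.1 percentage points higher from compound 3 to compound 4 (beyond the scatter)). The new information lies at the far end of the chain: methyl in place of hydrogen, six bonds along the chain from an aromatic carbon, leaves the two compounds indistinguishable (a number 3.3 percentage points higher from compound 2 to compound 4 (within the scatter)), so the chain-length trend seen from compound 3 to compound 2 does not extend measurably to compound 4, and among these all-carbon chains the maximal response has levelled off. Nothing available here accounts for this flattening.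

As far as these compounds go, whether a longer chain than that of compound 4 holds the response at this level or lowers it remains open. Also open, from the compounds shown here alone, is how a hydroxyl, an amine or a carboxylic acid at the chain end would compare with the nitrile of compound 1 and with the all-carbon ends.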